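A few compounds are considered here, and "the series" means these few. Any claim that something is new, unique, unknown or untested is made for them only; others in the source may bear on it.

Measured in a functional assay on MM1 cells (Homo sapiens) for antiproliferative activity, read by MTT assay, with a stated time of 72 h; on this read-out lower numbers stand for stronger inhibition and higher numbers for weaker inhibition:
- compound 1 `C[C@H](NC(=O)/C(C#N)=C/c1cccc(Br)n1)c1ccc(Br)cc1`: 1500 nM
- compound 2 `CC[C@H](NC(=O)/C(C#N)=C/c1cccc(Br)n1)c1ccccc1`: 1100 nM
- compound 3 `COC(=O)C[C@H](NC(=O)/C(C#N)=C/c1cccc(Br)n1)c1ccccc1`: 3100 nM

Of these three, compound 3 gives the highest number, 3100 nM. Compound 4 `CC(=O)OC[C@H](NC(=O)/C(C#N)=C/c1cccc(Br)n1)c1ccccc1` differs from it by one change: acetoxy in place of methoxycarbonyl on a saturated chain carbon, two bonds along the chain from an amide-type nitrogen and an aromatic carbon. The two have the same atoms, joined differently. Among the measured compounds shown here, only one measured step touches this place, a 2.8-fold higher number from compound 2 to compound 3 (0.45 log units; beyond the scatter), and there methoxycarbonyl replaced methyl. For the measured compounds named here, no measured step exchanges methoxycarbonyl for acetoxy, so that modest step only loosely bounds what may happen here. In this assay, little movement beyond the scatter is therefore expected, in neither direction with confidence. The expected step is a 1.2-fold lower number from compound 3 to compound 4 (0.08 log units; within the scatter). For compound 4 the estimated value is 2600 nM, with an expected range of 1200 nM to 5600 nM.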

Compound 4, half-maximal inhibitory concentration: 2600 nM
The estimate for compound 4 equals the measured number at the digits printed; the measured number falls inside the stated range.
By their numbers in this assay, from the lowest: compounds 2, 1, 4 and 3 (each within the scatter of the next, the first and the last beyond it).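

In this assay acetoxy in place of methoxycarbonyl on this saturated chain carbon gives a 1.2-fold lower number from compound 3 to compound 4 (0.08 log units; within the scatter) so these two groups, with the same atoms joined differently, are not told apart here. Acetoxy in place of methyl gives a 2.4-fold higher number from compound 2 to compound 4 (0.37 log units; beyond the scatter) so the rise seen earlier with methoxycarbonyl is not confined to that one group. Nothing available explains these numbers. Open, as far as these compounds go, is how a carboxylic acid, an amine or a hydroxymethyl at this carbon would read. So is whether a longer chain carrying either group would stay in this range.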